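Aryl swap on the anilino nitrogen of compound 3

The source may report more compounds than this note shows. Statements on the series, on what has been measured and on what is new or still open speak of the compounds shown alone.

Compound 3 `C=CC(=O)Nc1cccc(NC(=O)CSc2nc(Nc3cccc(Cl)c3)c3ccccc3n2)c1` gives 12300 nM in a functional assay on PC-3 cells (Homo sapiens) for inhibition, read by MTT assay, with a stated time of 72 h (on this read-out higher numbers stand for weaker inhibition and lower numbers for stronger inhibition), the second highest of three numbers; compound 2 `O=C(CSc1nc(Nc2ccccc2)c2ccccc2n1)Nc1ccc(Cl)cc1` gives 12900 nM and compound 1 `COc1cccc(NC(=O)CSc2nc(Nc3ccccc3)c3ccccc3n2)c1` gives 11600 nM, all three within the scatter of one another. Compound 4 `C=CC(=O)Nc1cccc(NC(=O)CSc2nc(Nc3ccc(C(F)(F)F)cc3)c3ccccc3n2)c1` differs from compound 3 by 4-(trifluoromethyl)phenyl in place of 3-chlorophenyl on a nitrogen on an aromatic ring. Within the data shown here, no measured step touches this nitrogen: the only step in hand, a 1.1-fold higher number from compound 1 to compound 2 (0.05 log units; within the scatter), alters the amide-type nitrogen instead and stays within the scatter. Among the measured compounds shown here, with three near-identical numbers and no step on the anilino aryl, the step from compound 3 to compound 4 in this assay is expected to stay within the scatter, a 1.0-fold lower number from compound 3 to compound 4 (0.01 log units; within the scatter). Compound 4 is therefore estimated at 12000 nM, between 5000 nM and 30000 nM.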

Compound 4, half-maximal inhibitory concentration: 12500 nM
Estimate against measurement, compound 4: 1.0-fold (0.02 log units) below; low and high end bracket the measured number.
By their numbers in this assay, from the lowest: compounds 1, 3, 4 and 2 (each within the scatter of the next).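

In this assay, among these compounds, this is the first step read on this nitrogen: a 1.0-fold higher number from compound 3 to compound 4 (0.01 log units; within the scatter). Between these two compounds, 4-(trifluoromethyl)phenyl therefore stands in place of 3-chlorophenyl on a nitrogen on an aromatic ring with no difference beyond the scatter. Nothing at hand gives a reason for this result.

Still open, going by these compounds, is whether an aryl group carrying an amine or a carboxylic acid on this nitrogen would give a step beyond the scatter. The same question stands for a longer alkyl chain in place of the aryl group.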